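Adding a phenyl group to compound 1

The source may hold more compounds than are shown below. What is called first, only, known or untested is meant among the compounds shown, and "the series" means these compounds.

Among the measured compounds shown here, in a functional assay on RAW264.7 cells (Mus musculus) for inhibition, read by ELISA, with a stated time of 24 h (on this read-out higher numbers stand for an effect only at larger amounts of compound and lower numbers for an effect already at smaller amounts), compound 1 `CC/C=C\C[C@H]1C(=O)C=C[C@H]1CC(=O)OCC` gives 20000 nM while its only measured neighbour, compound 2 `CC/C=C\C[C@H]1C(=O)C=C[C@H]1CC(=O)OCCOCCO`, gives 36000 nM in the same range. Compound 3 `CC/C=C\C[C@H]1C(=O)C=C[C@H]1CC(=O)OC(C)c1ccccc1` has not been measured and differs from compound 1 through phenyl in place of hydrogen on a saturated chain carbon bound to an oxygen next to a carbonyl group and a saturated chain carbon on the same side of the molecule's carbonyl-bound oxygen. For the measured compounds named here, the only measured guide is a 1.8-fold higher number from compound 1 to compound 2 (0.26 log units; within the scatter) for a different added group, 2-hydroxyethoxy, so no step beyond the scatter is expected. The change expected from this estimate is a 1.3-fold lower number from compound 1 to compound 3 (0.12 log units; within the scatter) and carries no firm direction. Compound 3 is estimated at 15000 nM with 6000 nM to 40000 nM as the expected range.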

Compound 3, half-maximal effective concentration: 18000 nM
The estimate for compound 3 lay 1.2-fold (0.08 log units) below the measured number, within the range that was stated.
By their numbers in this assay, from the lowest: compounds 3, 1 and 2 (each within the scatter of the next).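

In this assay, phenyl in place of hydrogen on the saturated chain carbon bound to an oxygen next to a carbonyl group gives a 1.1-fold lower number from compound 1 to compound 3 (0.05 log units; within the scatter). This shows that a six-membered aromatic ring of carbon only can be placed on this carbon with no step beyond the scatter, which the step with 2-hydroxyethoxy, made at a different carbon, could not show. No evidence is available to explain this result.

Still open, as far as these compounds go, is whether an amine or a carboxylic acid on this same carbon would give a step beyond the scatter.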